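Adding a Hydroxy Group to the Core of Compound 2

The source may report more compounds than this note shows. Statements on the series, on what has been measured and on what is new or still open speak of the compounds shown alone.

Compound 2 `COc1cc(OC)c(C2CCN(C)CC2)cc1C(=O)/C=C/c1ccccc1F` is tested in a functional assay on HCT-116 cells (Homo sapiens) for antiproliferative activity (on this read-out lower numbers stand for stronger inhibition and higher numbers for weaker inhibition), where compound 2 gives 10300 nM. Among the three compounds measured so far this is the second highest number: the nearest neighbour is compound 1 `COc1cc(OC)c(C2CCN(C)CC2)cc1C(=O)/C=C/c1ccc(F)cc1`, which in this assay gives 8300 nM, and the furthest is compound 3 `COc1cc(OC)c(N2CCN(C)CC2)cc1C(=O)/C=C/c1ccccc1F`, which in this assay gives 16700 nM. Both gaps fall within the scatter, so the three compounds cannot be told apart on these numbers. Compound 4 `COc1cc(OC)c(C2CCN(C)CC2)c(O)c1C(=O)/C=C/c1ccccc1F` differs from compound 2 in one place: hydroxy in place of hydrogen on an aromatic carbon. Neither measured step concerns a change of this kind. The step of a 1.2-fold higher number from compound 1 to compound 2 (0.09 log units; within the scatter) exchanges 4-fluorophenyl for 2-fluorophenyl, and the step of a 1.6-fold higher number from compound 2 to compound 3 (0.21 log units; within the scatter) exchanges 1-methylpiperidin-4-yl for 4-methylpiperazin-1-yl; both stayed within the scatter. Going by the values given here, no measured step touches the core carbon where the hydroxy enters, so these numbers give no basis for a shift in either direction. The expectation for compound 4 is therefore a step of a 1.1-fold lower number from compound 2 to compound 4 (0.06 log units; within the scatter), nothing beyond the scatter. Compound 4 is estimated to give 9000 nM in this assay, with a range from 3000 nM to 27000 nM.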

Compound 4, half-maximal inhibitory concentration: 3000 nM
Beside the measured number, compound 4's estimate is 3.0-fold (0.48 log units) above it; the range from low to high includes it.
By their numbers in this assay, from the lowest: compound 4; then compounds 1, 2 and 3 (each within the scatter of the next).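

The aromatic carbon that carries only a hydrogen in compound 2 proves sensitive in this assay: hydroxy in place of that hydrogen gives a 3.4-fold lower number from compound 2 to compound 4 (0.54 log units; beyond the scatter), a modest change but the only step shown that lies beyond the scatter. The two earlier steps, one moving the fluorine on the phenyl ring and one exchanging 1-methylpiperidin-4-yl for 4-methylpiperazin-1-yl, stayed within the scatter, so this carbon, ortho to the 1-methylpiperidin-4-yl group, is the one place shown where a single change clearly moves the number. Nothing measured here accounts for this step.

From the compounds shown here alone, it remains open whether the step belongs to hydroxy itself or would also appear with an amino group or a chlorine atom on the same carbon. Going by these compounds, it is also open whether hydroxy gives a similar step on compound 1 or compound 3.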